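Swapping a Methoxyphenyl for Thiophene on a Shared Core

This account rests on a few compounds, and the source may have more. Where it says the series, first, only, none or still open, it means among the compounds named here.

Measured in an assay on isolated protein for agonist activity at Bile acid receptor (Homo sapiens), read by AlphaScreen, with a stated time of 30 min; a higher number here means that more compound is needed for the effect, a lower number that less compound is needed:
compound 1 `Cc1ccccc1-n1nc(C)c2c1NC(=O)[C@H](C)S[C@@H]2c1ccc(-c2ccoc2)cc1`: 3500 nM
compound 2 `COc1cccc(-c2ccc([C@H]3S[C@@H](C)C(=O)Nc4c3c(C)nn4-c3ccccc3C)cc2)c1`: 1800 nM
compound 3 `Cc1nn(-c2ccccc2I)c2c1C(c1ccc(Oc3ccccc3)cc1)SC(C)C(=O)N2`: 1300 nM

Compound 2 sits between the other two numbers, with compound 3 on one side and compound 1 on the other, yet both gaps lie within the scatter, so the three compounds cannot be told apart on these data. Compound 4 `Cc1ccccc1-n1nc(C)c2c1NC(=O)[C@H](C)S[C@@H]2c1ccc(-c2ccsc2)cc1` differs from compound 2 in one place: thiophen-3-yl in place of 3-methoxyphenyl on an aromatic carbon. Among the compounds with values here, one measured step bears on this: a 1.9-fold lower number from compound 1 to compound 2 (0.29 log units; within the scatter), where furan-3-yl gave way to 3-methoxyphenyl. The change to compound 4 runs the other way, from 3-methoxyphenyl back to a five-membered aromatic ring with 1 hetero atom, thiophen-3-yl. A step of about the same size in the reverse direction is therefore expected, giving an estimated 1.7-fold higher number from compound 2 to compound 4 (0.22 log units; within the scatter), which stays within the scatter. Compound 4 is thus expected to land near compound 1, at an estimated 3000 nM, with a range from 1000 nM to 9000 nM.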

Compound 4, half-maximal effective concentration: 1400 nM
Beside the measured number, compound 4's estimate is 2.1-fold (0.33 log units) above it; measured number inside the range.
By their numbers in this assay, from the lowest: compounds 3, 4, 2 and 1 (each within the scatter of the next, the first and the last beyond it).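

In this assay, moving from a six-membered carbon ring to a five-membered ring barely registers at this position, para to a large group (a 1.3-fold lower number from compound 2 to compound 4 (0.11 log units; within the scatter)), a step within the scatter. Within the data shown here, the earlier compounds offered only steps within the scatter, whereas exchanging one five-membered ring for the other gives the first step beyond it, though a modest one (a 2.5-fold lower number from compound 1 to compound 4 (0.40 log units; beyond the scatter)), so the identity of the hetero atom can matter here even with ring size unchanged. No measurement is at hand that explains this difference between the two rings. All the groups shown at this position are aromatic rings, so the effect of an amine, a carboxylic acid or a longer chain there remains open. Also open, from the compounds shown here alone, is whether the step between the two five-membered rings would hold on another core, such as that of compound 3.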